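The compounds below may be only part of what the source reports. "The series", "measured", "known", "first", "only" and "open" are said of these compounds alone.

Three compounds built on one shared core carry hydroxyphenyl groups that differ only in where the hydroxyl sits. In a functional assay on DU-145 cells (Homo sapiens) for cytotoxicity, read by CCK-8 assay, with a stated time of 4 days (a higher number here means a weaker inhibitor, a lower number a stronger inhibitor), compound 1 `Oc1ccc(-c2cc(-c3ccccc3O)cc(-c3cccc(O)c3)n2)cc1` gives 5370 nM, and compound 2 `Oc1cccc(-c2cc(-c3ccccc3O)nc(-c3ccccc3O)c2)c1` gives 5400 nM. For compound 3 `Oc1cccc(-c2cc(-c3cccc(O)c3)nc(-c3ccccc3O)c2)c1` this assay reports only a limit, > 50000 nM, so compound 3 stands at the weak end of what was measured. Among the compounds with values here, the single measured step, an at least 9.2-fold higher number from compound 2 to compound 3 (0.96 log units; beyond the scatter), swapped a 2-hydroxyphenyl for a 3-hydroxyphenyl and weakened inhibition. Compound 4 `Oc1ccc(-c2cc(-c3cccc(O)c3)cc(-c3cccc(O)c3)n2)cc1` differs from compound 3 by 4-hydroxyphenyl in place of 2-hydroxyphenyl on an aromatic carbon, again removing a 2-hydroxyphenyl. Compound 4 is therefore expected to remain weak, with an estimated step that the limit leaves unreadable from compound 3 to compound 4 and a value near 60000 nM, ranging from 15000 nM to 200000 nM, quite possibly reported only as a limit.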

Compound 4, half-maximal inhibitory concentration: 1940 nM
Beside the measured number, compound 4's estimate is 31-fold (1.49 log units) above it, and the stated range ends above it.
By their numbers in this assay, from the lowest: compound 4; then compounds 1 and 2 (each within the scatter of the next). At a limit, above all of these: compound 3.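

In this assay, losing the 2-hydroxyphenyl does not by itself leave a compound weak: 4-hydroxyphenyl in its place, next to the ring nitrogen, gives an at least 25-fold lower number from compound 3 to compound 4 (1.41 log units; beyond the scatter). A different swap, 3-hydroxyphenyl in place of 2-hydroxyphenyl, gives a 2.8-fold lower number from compound 1 to compound 4 (0.44 log units; beyond the scatter), so this change does not act the same way on every core: the same change on two cores in this assay, an at least 9.2-fold higher number (0.96 log units; beyond the scatter) from compound 2 to compound 3 and a 2.8-fold lower number (0.44 log units; beyond the scatter) from compound 1 to compound 4, at least 25-fold (1.40 log units) apart, beyond the scatter of two such steps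

Going by these compounds, compound 3 has only a limit, > 50000 nM, so the full size of its step to compound 4 stays open. Also open, on these data alone, is what a methoxyphenyl or an aminophenyl group would do at this position.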